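Swapping a Cyclohexyl for an Oxazolyl Group on the Amine

The source may hold more compounds than are shown below. What is called first, only, known or untested is meant among the compounds shown, and "the series" means these compounds.

Of the compounds shown here, two built on a shared core have been measured in an assay on HEK293 cells for displacement of a labelled ligand from growth hormone secretagogue receptor type 1 (Homo sapiens), with a stated time of 60 min; on this read-out lower numbers stand for stronger inhibition and higher numbers for weaker inhibition. Compound 1 `COc1cccc(-n2cc3nc(-c4cccnc4C)n(C[C@H]4CCCN(CC5CCCCC5)C4)c(=O)c3n2)c1` gives 200 nM in this assay, and compound 2 `Cc1ncccc1-c1nc2cn(-c3ccccc3)nc2c(=O)n1C[C@H]1CCCN(C[C@H]2CCCO2)C1` gives 190 nM. Of these two numbers, that of compound 1 is the higher, but its gap to compound 2 lies within the usual scatter, so the two cannot be told apart on this read-out. Compound 3 `COc1cccc(-n2cc3nc(-c4cccnc4C)n(C[C@H]4CCCN(Cc5cnco5)C4)c(=O)c3n2)c1` has not yet been measured in this assay. It differs from compound 1 in a single place: 1,3-oxazol-5-yl in place of cyclohexyl on a saturated chain carbon bound to an amine nitrogen in a ring. Within the data shown here, no measured pair isolates this change, so its size and direction are open. Compound 3 is expected to give about 400 nM in this assay, with a likely range from 120 nM to 1500 nM. This estimate means a step of a 2.0-fold higher number from compound 1 to compound 3 (0.30 log units; within the scatter), a modest weakening that could well stay inside the scatter.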

Compound 3, half-maximal inhibitory concentration: 120 nM
Estimate against measurement, compound 3: 3.3-fold (0.52 log units) above, and the stated range covers the measured number.
By their numbers in this assay, from the lowest: compounds 3, 2 and 1 (each within the scatter of the next).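

In this assay, replacing cyclohexyl with 1,3-oxazol-5-yl on a saturated chain carbon bound to an amine nitrogen in a ring gives a 1.7-fold lower number from compound 1 to compound 3 (0.22 log units; within the scatter), so the two groups cannot be told apart on this read-out. Among these compounds, this pair is the first to isolate the position, and it shows that a six-membered non-aromatic ring of carbon only and a five-membered aromatic ring with 2 hetero atoms, which brings 2 hydrogen-bond acceptors, give indistinguishable numbers here. No independent measurement is available to explain this result.

The compounds shown leave open whether an amine, a carboxylic acid or a longer chain in place of 1,3-oxazol-5-yl would shift the number beyond the scatter. As far as these compounds go, whether a thiazolyl or a phenyl group would read the same as 1,3-oxazol-5-yl also remains open.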